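Swapping the aryl on the ring amide nitrogen for pyrimidin-5-yl

The source may hold more compounds than are shown below. What is called first, only, known or untested is meant among the compounds shown, and "the series" means these compounds.

The measured compounds and their numbers:
compound 1 `CO[C@@H]1CC=C2NN(c3ccc(Cl)cc3)C(=O)C[C@]2(C)O1` — 25500 nM
compound 2 `CO[C@@H]1CC=C2NN(c3cccnc3)C(=O)C[C@]2(C)O1` — 14400 nM
compound 3 `CO[C@@H]1CC=C2NN(c3ccc(C)cc3)C(=O)C[C@]2(C)O1` — 21500 nM

All three were tested in a functional assay on A549 cells (Homo sapiens) for inhibition, read by sulforhodamine B assay, with a stated time of 48 h; a higher number here means a weaker inhibitor, a lower number a stronger inhibitor. Compound 3 sits second highest of the three; its nearest neighbour is compound 1, and the gap between the two, a 1.2-fold lower number from compound 1 to compound 3 (0.07 log units; within the scatter), stays within the scatter. The gap to compound 2, a 1.5-fold higher number from compound 2 to compound 3 (0.17 log units; within the scatter), is also within the scatter, so nothing here separates the three compounds.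

Compound 4 `CO[C@@H]1CC=C2NN(c3cncnc3)C(=O)C[C@]2(C)O1` is the next step. It differs from compound 3 in one place: pyrimidin-5-yl in place of 4-methylphenyl on an amide-type nitrogen in a ring. Among the compounds with values here, the closest precedent is the exchange of the aryl group on the same nitrogen already seen, a 1.5-fold higher number from compound 2 to compound 3 (0.17 log units; within the scatter), and the related exchange a 1.8-fold lower number from compound 1 to compound 2 (0.25 log units; within the scatter); both stayed within the scatter. On that basis no step beyond the scatter is expected for a 1.3-fold lower number from compound 3 to compound 4 (0.10 log units; within the scatter). Compound 4 is therefore estimated at 17000 nM, with a range from 7000 nM to 40000 nM.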

Compound 4, half-maximal inhibitory concentration: 4100 nM
Compound 4: the middle estimate sits 4.1-fold (0.62 log units) above what was measured, and the stated range ends above it.
By their numbers in this assay, from the lowest: compound 4; then compounds 2, 3 and 1 (each within the scatter of the next).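

In this assay, within the data shown here, this place on the amide-type nitrogen proves sensitive to the aryl exchange, which the earlier compounds, all within the scatter of one another, did not show: pyrimidin-5-yl gives a 5.2-fold lower number from compound 3 to compound 4 (0.72 log units; beyond the scatter) and also a 3.5-fold lower number from compound 2 to compound 4 (0.55 log units; beyond the scatter) and a 6.2-fold lower number from compound 1 to compound 4 (0.79 log units; beyond the scatter) with all three steps beyond the scatter. Pyridin-3-yl does not share this separation, since compound 2 stays within the scatter of compound 1 and compound 3, so among these four compounds the step appears only with pyrimidin-5-yl, the group counted with 2 hetero atoms and 2 hydrogen-bond acceptors. Nothing available here explains the step.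

The compounds shown leave open whether the step depends on where the ring nitrogens stand, as a pyrazin-2-yl or pyrimidin-2-yl group would test. They also leave open how a pyrimidin-5-yl ring carrying an amine or a methoxy group would read.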